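Swapping benzoyl for cyano on a sulfonyl vinyl indole

The source may report more compounds than this note shows. Statements on the series, on what has been measured and on what is new or still open speak of the compounds shown alone.

Compound 1 `COc1ccc(-c2[nH]c3ccccc3c2/C=C(\C#N)S(=O)(=O)c2ccccc2)cc1` gives 344 nM in a functional assay on SK-MEL-5 cells (Homo sapiens) for inhibition, read by sulforhodamine B assay, with a stated time of 48 h; a higher number here means a weaker inhibitor of growth, a lower number a stronger inhibitor of growth.
Compound 2 `CCOC(=O)C(=Cc1c(-c2ccccc2)[nH]c2ccccc12)C(=O)OCC` gives 3800 nM in this assay.
Compound 3 `O=C(/C(=C\c1c(-c2ccccc2)[nH]c2ccccc12)S(=O)(=O)c1ccccc1)c1ccccc1` gives 9000 nM in this assay.

Among these three, compound 3 has the highest number, the weakest growth inhibition; compound 2 stands nearest to it and compound 1 furthest, both gaps beyond the scatter. Compound 4 `N#C/C(=C\c1c(-c2ccccc2)[nH]c2ccccc12)S(=O)(=O)c1ccccc1` is not yet measured. It differs from compound 3 by cyano in place of benzoyl on a double-bonded chain carbon bound to a double-bonded chain carbon and a sulfonyl sulfur. Going by the values given here, no measured pair shows this exact step, so the expected size is inferred. Compound 4 is expected to inhibit growth considerably more strongly than compound 3, because compound 1, which carries the same cyano and sulfonyl on the double-bonded chain carbon, gives 344 nM. The estimated step of a 13-fold lower number from compound 3 to compound 4 (1.11 log units; beyond the scatter) is expected to lie well beyond the scatter. Compound 4 is estimated at 700 nM, within 250 nM to 2500 nM.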

Compound 4, concentration for 50% growth inhibition: 1820 nM
Compound 4: the middle estimate sits 2.6-fold (0.41 log units) below what was measured; the measured number falls inside the stated range.
By their numbers in this assay, from the lowest: compound 1; then compound 4; then compound 2; then compound 3.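

In this assay cyano in place of benzoyl gives a 4.9-fold lower number from compound 3 to compound 4 (0.69 log units; beyond the scatter) and so shows, at this double-bonded chain carbon, that the cyano compound is the stronger inhibitor of growth. Hydrogen in place of methoxy on an aromatic carbon gives a 5.3-fold higher number from compound 1 to compound 4 (0.72 log units; beyond the scatter) and so shows that the methoxy also counts towards the strength of compound 1. Nothing measured here explains either step.

As far as these compounds go, whether an amide or a carboxylic acid could replace the cyano at this carbon remains open, as does the effect of a fluorine in place of the methoxy.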